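Replacing pyrazolyl with bromo in a cytotoxic series

The source may hold more compounds than are shown below. What is called first, only, known or untested is meant among the compounds shown, and "the series" means these compounds.

Compound 1 `Cc1cc(Nc2ccc(C(=O)/C=C/c3ccc(Cl)cc3)cc2)n2nc(SCc3nc4ccccc4[nH]3)nc2n1` gives 230 nM 
Compound 2 `Cc1cc(Nc2ccc(C(=O)/C=C/c3ccc(-n4cccn4)cc3)cc2)n2nc(SCc3nc4ccccc4[nH]3)nc2n1` gives 340 nM 

In a functional assay on SW-620 cells (Homo sapiens) for cytotoxicity, read by MTT assay, with stated times of 4 h and 72 h, tested at 2 uM (on this read-out higher numbers stand for weaker inhibition and lower numbers for stronger inhibition), compound 2 lies within the scatter of compound 1, so the two cannot be ranked. Compound 3 `Cc1cc(Nc2ccc(C(=O)/C=C/c3ccc(Br)cc3)cc2)n2nc(SCc3nc4ccccc4[nH]3)nc2n1` carries bromo in place of 1H-pyrazol-1-yl on an aromatic carbon. Among the compounds with values here, only one measured step bears on this change, the exchange of chloro for that same 1H-pyrazol-1-yl, and it was small (a 1.5-fold higher number from compound 1 to compound 2 (0.17 log units; within the scatter)). No shift beyond the scatter is therefore expected in this assay. The expected step is small and its number is estimated (a 1.4-fold lower number from compound 2 to compound 3 (0.13 log units; within the scatter)). For compound 3 the estimated value is 250 nM (expected range 120 nM to 520 nM).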

Compound 3, half-maximal inhibitory concentration: 290 nM
For compound 3 the middle estimate is 1.2-fold (0.06 log units) below the measured one; low and high end bracket the measured number.
By their numbers in this assay, from the lowest: compounds 1, 3 and 2 (each within the scatter of the next).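

In this assay, the new compound adds a third group at this place on the aromatic ring, and the numbers still cannot be ranked: a 1.2-fold lower number from compound 2 to compound 3 (0.07 log units; within the scatter), and a 1.3-fold higher number from compound 1 to compound 3 (0.10 log units; within the scatter). Bromo, with 1 heavy atom, thus stays within the scatter of 1H-pyrazol-1-yl, with 5 heavy atoms and a ring of its own, and also of chloro. No available measurement explains why these groups read alike. From the compounds shown here alone, whether an amine or a carboxylic acid at this place would also stay within the scatter remains open.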